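Swapping dimethylamino for tert-butyl on the shared core

The compounds below may be only part of what the source reports. "The series", "measured", "known", "first", "only" and "open" are said of these compounds alone.

Going by the values given here, compound 2 `CN(C)c1ccc(C(C)(C)NC(=O)c2ccc([N+](=O)[O-])o2)cc1` holds the only true number in an ADME assay on Vero cells (Chlorocebus sabaeus) for cytotoxicity, read by MTT assay, with a stated time of 48 h (a higher number here means that more compound is tolerated, a lower number that less compound is tolerated), where compound 2 gives 79000 nM. Compound 1 `CC(C)(NC(=O)c1ccc([N+](=O)[O-])o1)c1ccccc1` reaches only a limit of the assay, > 180000 nM. Among the compounds with values here, the single measured step, an at least 2.2-fold lower number from compound 1 to compound 2 (0.35 log units; beyond the scatter), starts from the limit of > 180000 nM in this assay, at which 1 of the 2 values shown sits. Compound 3 `CC(C)(C)c1ccc(C(C)(C)NC(=O)c2ccc([N+](=O)[O-])o2)cc1` differs from compound 2 by tert-butyl in place of dimethylamino on an aromatic carbon. Within the data shown here, no measured step swaps one such group for another, so that step gives only loose guidance, and a change of its size is possible in either direction. Compound 3 is expected to give about 100000 nM, within 35000 nM to 250000 nM. The expected step of a 1.3-fold higher number from compound 2 to compound 3 (0.10 log units; within the scatter) is therefore modest at most.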

Compound 3, half-maximal cytotoxic concentration: > 150000 nM
Compound 3 was reported as a limit; the forecaster's own chance of this, stated with the estimate: 30%; middle value at least 1.5-fold (0.17 log units) from the limit.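

With tert-butyl in place of dimethylamino, this assay shows an at least 1.8-fold higher number from compound 2 to compound 3 (0.27 log units; that floor lies within the scatter), so the true gap could be wider, but what is shown does not clear the usual scatter. Compound 3 gives only a limit, not a number: the limit of > 150000 nM in this assay, at which 1 of the 3 values shown sits. Compound 2, with dimethylamino, is the only one of the three to give a true number, and the step from compound 1 to compound 3 cannot be read.

From the compounds shown here alone, whether a primary amine or a carboxylic acid at this place would give a true number remains open.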